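Swapping a pyrazole for a piperidine on the sulfonyl

The source may report more compounds than this note shows. Statements on the series, on what has been measured and on what is new or still open speak of the compounds shown alone.

Measured compounds:
compound 1 `O=C(NCc1ccc(S(=O)(=O)c2cc(F)cc(F)c2)cc1)N1Cc2ccncc2C1` gives 8 mL/min/kg
compound 2 `CCCn1cc(S(=O)(=O)c2ccc(CNC(=O)N3Cc4ccncc4C3)cc2)cn1` gives 11 mL/min/kg
compound 3 `CCC(=O)N1CCC(S(=O)(=O)c2ccc(CNC(=O)N3Cc4ccncc4C3)cc2)CC1` gives 11 mL/min/kg

These three share one core and differ only in the group attached to the sulfonyl sulfur. In an ADME assay on microsomes from liver (Homo sapiens) for pharmacokinetics, read by LC-MS, with a stated time of 60 min, tested at 1 uM (on this read-out lower numbers stand for slow clearance and higher numbers for fast clearance), compound 2 stands level with compound 3, and the two together hold the highest numbers of the three, while compound 1 sits nearest below them. Every gap among them lies within the scatter: a 1.4-fold higher number from compound 1 to compound 2 (0.14 log units; within the scatter), a 1.4-fold higher number from compound 1 to compound 3 (0.14 log units; within the scatter) and no change at the digits printed from compound 2 to compound 3 (within the scatter). In other words, three quite different groups on the sulfonyl sulfur have given the same read-out within the usual noise.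

Compound 4 `CN1CCC(S(=O)(=O)c2ccc(CNC(=O)N3Cc4ccncc4C3)cc2)CC1` has not yet been measured. It differs from compound 2 at the same position: 1-methylpiperidin-4-yl in place of 1-propyl-1H-pyrazol-4-yl on a sulfonyl sulfur. Among the measured compounds shown here, the step that bears most closely on it is the one to compound 3, where a saturated six-membered ring replaced the pyrazole and the number did not move. Compound 4 also carries a six-membered non-aromatic ring with one hetero atom, so no change beyond the scatter is expected in this assay, with the step from compound 2 estimated as a 1.1-fold higher number from compound 2 to compound 4 (0.04 log units; within the scatter). Compound 4 is therefore expected to give 12 mL/min/kg, with a likely range from 6 mL/min/kg to 25 mL/min/kg.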

Compound 4, clearance: 11 mL/min/kg
Beside the measured number, compound 4's estimate is 1.1-fold (0.04 log units) above it; the range from low to high includes it.
By their numbers in this assay, from the lowest: compounds 1, 2, 3 and 4 (each within the scatter of the next).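

In this assay, placing 1-methylpiperidin-4-yl on the sulfonyl sulfur in place of 1-propyl-1H-pyrazol-4-yl gives no change at the digits printed from compound 2 to compound 4 (within the scatter) and so adds a second saturated ring that reads like the pyrazole, this time one with a single hetero atom and no carbonyl on its ring nitrogen. Among the compounds shown here, the new result also gives the first look at a change on the amine nitrogen in the ring, since methyl in place of propanoyl gives no change at the digits printed from compound 3 to compound 4 (within the scatter) even though the entering group is far smaller than the one it replaces. Set against the aromatic 3,5-difluorophenyl group, the same piperidine gives a 1.4-fold higher number from compound 1 to compound 4 (0.14 log units; within the scatter) and so all four groups shown on the sulfonyl sulfur now read alike within the usual scatter, with no compound among them going against that. Still open is whether this tolerance extends to a longer chain on the ring nitrogen, such as butyl, or to a carboxylic acid on the piperidine ring, both of which lie outside the compounds shown. Why these quite different groups read alike in this measurement cannot be told from anything available here.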